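The source may hold more compounds than are shown below. What is called first, only, known or untested is meant among the compounds shown, and "the series" means these compounds.

Compound 3 `COc1ccc2c(=O)c(/C=C/C(=O)Nc3ccccc3Cl)coc2c1` carries a 2-chlorophenyl group on the amide nitrogen of the shared core. In a functional assay on HeLa cells (Homo sapiens) for inhibition, read by MTT assay, with a stated time of 48 h (on this read-out higher numbers stand for weaker inhibition and lower numbers for stronger inhibition), compound 3 gives 22400 nM. For the measured compounds named here, this is the only plain number among the three measured compounds, because the other two sit at the limit of > 100000 nM in this assay, at which 2 of the 3 values shown sit. Compound 1 `COc1ccc2c(=O)c(/C=C/C(=O)Nc3cccc(C)c3)coc2c1` reaches only a limit: in this assay compound 1 gives > 100000 nM. Compound 2 `COc1ccc2c(=O)c(/C=C/C(=O)Nc3ccccc3)coc2c1` likewise stops at a limit, giving > 100000 nM in this assay. The step from compound 1 to compound 3 is an at least 4.4-fold lower number from compound 1 to compound 3 (0.64 log units; beyond the scatter), and the step from compound 2 to compound 3 is an at least 4.4-fold lower number from compound 2 to compound 3 (0.64 log units; beyond the scatter); between compound 1 and compound 2 the step is a step that the two limits leave unreadable from compound 1 to compound 2.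

Compound 4 `COc1ccc2c(=O)c(/C=C/C(=O)Nc3cc(C)ccc3C)coc2c1` differs from compound 3 by 2,5-dimethylphenyl in place of 2-chlorophenyl on an amide-type nitrogen. This change takes away the chloro whose arrival, in an at least 4.4-fold lower number from compound 2 to compound 3 (0.64 log units; beyond the scatter), went with a lower number, while compound 1, whose 3-methylphenyl carries a methyl and no chloro, stayed at a limit. A move back toward weaker inhibition is therefore expected in this assay, of about a 2.7-fold higher number from compound 3 to compound 4 (0.43 log units; beyond the scatter). For compound 4 the expected value in this assay is 60000 nM, with a range from 15000 nM to 150000 nM, and a real chance that only a limit is returned.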

Compound 4, half-maximal inhibitory concentration: 58400 nM
Compound 4: middle estimate off by 1.0-fold (0.01 log units), on the high side; low and high end bracket the measured number.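

Compound 4 shows that a chloro is not required for a readable number with a substituted phenyl on this amide-type nitrogen: 2,5-dimethylphenyl also gives a plain value in this assay, though swapping it in for 2-chlorophenyl costs strength, with a 2.6-fold higher number from compound 3 to compound 4 (0.42 log units; beyond the scatter). Any gain of compound 4 over the compounds without a plain value remains unproven, since the comparisons give only an at least 1.7-fold lower number from compound 2 to compound 4 (0.23 log units; that floor lies within the scatter) and an at least 1.7-fold lower number from compound 1 to compound 4 (0.23 log units; that floor lies within the scatter), and neither floor clears the usual scatter of repeated measurements. These two steps can only be read as floors, because the true values of compound 1 and compound 2 lie beyond what the assay reports: the limit of > 100000 nM in this assay, at which 2 of the 4 values shown sit.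

The compounds shown leave open how a fluoro, a methoxy or an amino group would compare with the chloro of compound 3 on the same phenyl ring. They also leave open whether the two methyl groups of compound 4 contribute equally, or whether one of them alone would give a plain value.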